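This account rests on a few compounds, and the source may have more. Where it says the series, first, only, none or still open, it means among the compounds named here.

Working notes on a small series sharing one core, read in a functional assay on HCT-116 cells (Homo sapiens) for inhibition, read by sulforhodamine B assay, with a stated time of 3 days; a higher number here means a weaker inhibitor of growth, a lower number a stronger inhibitor of growth. Compound 1 (`O=C(/C=C/c1ccc(OCc2ccccc2)cc1)c1ccccc1`) gives > 50000 nM, which is a limit of the assay and not a number. Compound 2 (`O=C(/C=C/c1ccc(Cl)cc1)c1ccccc1`) gives 16500 nM, a measured number. Compound 3 (`O=C(/C=C/c1ccc(F)cc1)c1ccc(OCc2ccccc2)cc1`) gives > 50000 nM, again a limit and not a number. Compound 3 thus stands at the limit of > 50000 nM in this assay, at which 2 of the 3 values shown sit, so no exact size can be read for a step that starts from it.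

The next compound is compound 4 (`O=C(/C=C/c1ccc(F)cc1)c1ccccc1`), with this change: hydrogen in place of benzyloxy on an aromatic carbon. Going by the values given here, one measured step bears on it: an at least 3.0-fold lower number from compound 1 to compound 2 (0.48 log units; beyond the scatter). That step also removes benzyloxy from an aromatic carbon, though at another place in the shared core, and chloro rather than hydrogen enters there. Among the three measured compounds, the two with benzyloxy are the two at the limit, and none goes against this. A step of at least modest size toward a lower number is therefore expected in this assay, given that compound 2 reads 16500 nM. The expected change is an at least 2.5-fold lower number from compound 3 to compound 4 (0.39 log units; beyond the scatter). Compound 4 is estimated at 20000 nM, with an expected range from 8000 nM to 50000 nM.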

Compound 4, concentration for 50% growth inhibition: 4360 nM
Compound 4: the middle estimate sits 4.6-fold (0.66 log units) above what was measured, and the stated range ends above it.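

In this assay, hydrogen in place of benzyloxy on an aromatic carbon gives an at least 11-fold lower number from compound 3 to compound 4 (1.05 log units; beyond the scatter), and fluoro in place of benzyloxy at the other place in the shared core gives an at least 11-fold lower number from compound 1 to compound 4 (1.05 log units; beyond the scatter), so a measured number appears when benzyloxy leaves either place. Benzyloxy is not the only group that sets the reading, as fluoro in place of chloro gives a 3.8-fold lower number from compound 2 to compound 4 (0.58 log units; beyond the scatter), a modest step that shows the halogen on that aromatic carbon also counts in this series. Compound 1 and compound 3 each read as a limit and not a number, so the two large steps give only a lower bound on their size: the limit of > 50000 nM in this assay, at which 2 of the 4 values shown sit.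

Open, from the compounds shown here alone, is whether a methoxy group, an amine or a carboxylic acid on the aromatic carbon that carries hydrogen in compound 4 would read like benzyloxy or like hydrogen. Also open, going by these compounds, is whether fluoro or chloro on that same carbon would lower the number further, and whether a bromo group or a nitrile in place of fluoro would continue the step seen from chloro to fluoro.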